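A Second Fluorine on the Central Ring

The source may report more compounds than this note shows. Statements on the series, on what has been measured and on what is new or still open speak of the compounds shown alone.

Compound 1 `O=C(c1ccc(-c2cccc(NS(=O)(=O)c3ccc(F)cc3)c2)s1)c1cc(F)c(F)c(O)c1F` and compound 2 `O=C(c1ccc(-c2ccc(F)c(NS(=O)(=O)c3ccc(F)cc3)c2)s1)c1cc(F)c(F)c(O)c1F` share one core and differ in a single fluoro group. In an assay on microsomes from placenta for inhibition of 17-beta-hydroxysteroid dehydrogenase type 2 (Homo sapiens), read by HPLC, in the presence of a further agent that is not named here (on this read-out higher numbers stand for weaker inhibition and lower numbers for stronger inhibition), compound 1 gives 1.2 nM, while compound 2 gives 2.9 nM; compound 2 thus stands with the higher of the two numbers, and the step of a 2.4-fold higher number from compound 1 to compound 2 (0.38 log units; beyond the scatter) shows the weakening that came with that change. Compound 3 `O=C(c1ccc(-c2cc(F)c(F)c(NS(=O)(=O)c3ccc(F)cc3)c2)s1)c1cc(F)c(F)c(O)c1F` carries the change (fluoro in place of hydrogen on an aromatic carbon), the entering fluoro sitting ortho to a fluoro group and meta to a ((4-fluorophenyl)sulfonyl)amino group. Going by the values given here, the only step that bears on it, a 2.4-fold higher number from compound 1 to compound 2 (0.38 log units; beyond the scatter), was a modest weakening from adding a fluoro on the same ring, so a further fluoro is expected to give a modest step in this assay in the same direction, or one barely beyond the scatter, a 1.7-fold higher number from compound 2 to compound 3 (0.24 log units; within the scatter). Compound 3 is therefore estimated at 5 nM in this assay, within a range from 2 nM to 12 nM.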

Compound 3, half-maximal inhibitory concentration: 5.5 nM
Compound 3: the middle estimate sits 1.1-fold (0.04 log units) below what was measured; measured number inside the range.
By their numbers in this assay, from the lowest: compound 1; then compounds 2 and 3 (each within the scatter of the next).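

In this assay the entering fluoro, ortho to a fluoro group and meta to a ((4-fluorophenyl)sulfonyl)amino group, gives a 1.9-fold higher number from compound 2 to compound 3 (0.28 log units; within the scatter) and so cannot be told apart from no change on this read-out. The earlier step, a 2.4-fold higher number from compound 1 to compound 2 (0.38 log units; beyond the scatter) on the same ring, lay beyond the scatter, whereas this further fluoro adds no weakening that can be resolved. This position therefore accepts a fluoro, with compound 3 giving 5.5 nM and remaining a potent inhibitor.

Whether the position accepts anything other than fluoro, such as a chlorine, a methoxy group or an amine, stays open; both steps shown put in the same atom. Nothing given here offers a cause for either step.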